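A Second Chloro on Compound 3

A few compounds are considered here, and "the series" means these few. Any claim that something is new, unique, unknown or untested is made for them only; others in the source may bear on it.

Measured in an ADME assay on Vero cells (Chlorocebus sabaeus) for cytotoxicity, read by MTT assay, with a stated time of 72 h; a higher number here means that more compound is tolerated, a lower number that less compound is tolerated:
Compound 1 `CC/C(=C\c1ccc(Cl)cc1)C(C)=O`: 136000 nM
Compound 2 `COc1ccc(/C=C(\C)C(=O)/C=C/c2cccc(Br)c2)cc1`: 153000 nM
Compound 3 `COc1ccc(/C=C(\C)C(=O)/C=C/c2ccccc2Cl)cc1`: 74300 nM

Compound 3 and compound 1 lie within the usual scatter of each other, so neither can be said to be better tolerated. Compound 2 is the closer structural relative of compound 3, and it is the only one separated from it by a single change.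

Compound 4 `COc1ccc(/C=C(\C)C(=O)/C=C/c2cccc(Cl)c2Cl)cc1` keeps all of compound 3 and makes one substitution: chloro in place of hydrogen on an aromatic carbon. The new chloro sits on an aromatic carbon, ortho to a chloro group.

Within the data shown here, no measured pair shows a chloro simply added to an aromatic ring. The nearest evidence is a 2.1-fold lower number from compound 2 to compound 3 (0.31 log units; beyond the scatter), in which a 2-chlorophenyl replaces a 3-bromophenyl. That step bears on the change only loosely, but it was modest, so a large move in this assay is not expected. A small drift towards a lower number is the best guess, with no step beyond the scatter expected.

The estimated step is a 1.1-fold lower number from compound 3 to compound 4 (0.06 log units; within the scatter). For compound 4 the expected value is 65000 nM, with an estimated range from 32000 nM to 130000 nM.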

Compound 4, half-maximal cytotoxic concentration: 119000 nM
The estimate for compound 4 lay 1.8-fold (0.26 log units) below the measured number; the measured number falls inside the stated range.
By their numbers in this assay, from the lowest: compounds 3, 4, 1 and 2 (each within the scatter of the next, the first and the last beyond it).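

In this assay, among these compounds, the step of a 1.6-fold higher number from compound 3 to compound 4 (0.20 log units; within the scatter) is the first direct reading of a chloro placed on this aromatic carbon, ortho to a chloro group and meta to a large group. The earlier comparison could speak to this change only loosely, since it swapped a 3-bromophenyl for a 2-chlorophenyl, whereas this pair differs only by chloro in place of hydrogen and shows that this position accepts the added chloro with no difference that can be told from the usual scatter between repeated measurements. Nothing available explains this result or shows what the added chloro does in the cells.

The compounds shown leave open whether a different group on this same aromatic carbon, such as an amine or a carboxylic acid, would produce a step beyond the scatter in this assay or stay as close to compound 3 as the chloro does. They also leave open whether a chloro on another carbon of this ring would give a similar result, since this single pair speaks only for the one position.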